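Butylcarbamoyl for Ethynyl: Expected Inhibition of Compound 3

The source may report more compounds than this note shows. Statements on the series, on what has been measured and on what is new or still open speak of the compounds shown alone.

Compound 1 `N#CCN(C/C=C/c1ccccc1)Cc1ccccc1` and compound 2 `C#CCN(Cc1ccccc1)Cc1ccc2ccccc2c1` were both run in an assay on HEK293 cells for binding affinity to Substance-K receptor (Rattus norvegicus), read by FRET, tested at 10 uM; on this read-out higher numbers stand for more inhibition at the one concentration tested (going by the name of the read-out) and lower numbers for less inhibition. Compound 1 gives 0% and compound 2 gives 0% in this assay, so compound 2 stands level with compound 1, within the scatter. Compound 3 `CCCCNC(=O)CN(Cc1ccccc1)Cc1ccc2ccccc2c1` differs from compound 2 by a single change: butylcarbamoyl in place of ethynyl on a saturated chain carbon bound to an amine nitrogen. Going by the values given here, no measured pair covers this change, so the expectation rests on compound 2 alone. The step of a number 5 percentage points higher from compound 2 to compound 3 (within the scatter) is expected to be small, not beyond the scatter, in no firm direction. Compound 3 is therefore estimated at 5% in this assay, within a range from -10% to 25%.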

Compound 3, a percentage reported as inhibition, at one concentration (the size of the read-out at that concentration, not a potency): 0%
Beside the measured number, compound 3's estimate is 5 percentage points above it; measured number inside the range.
By their numbers in this assay, from the lowest: compounds 1, 2 and 3 (each within the scatter of the next).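

In this assay, going by these compounds alone, the swap of ethynyl for butylcarbamoyl on a saturated chain carbon bound to an amine nitrogen gives no change at the digits printed from compound 2 to compound 3 (within the scatter) and so adds the first reading of a change at this position. The hydrogen-bond donor and acceptor entering with butylcarbamoyl do not separate compound 3 from compound 2 here. Nothing available explains this result. As far as these compounds go, whether a carboxylic acid, an amine or a longer chain at this position would give a reading different from that of compound 2 stays open.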